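The compounds below may be only part of what the source reports. "The series", "measured", "known", "first", "only" and "open" are said of these compounds alone.

Measured compounds:
compound 1, `CCOC(=O)CN(C)c1cc(OCc2cc(F)c(Oc3ccc(Cl)c(C(F)(F)F)c3)c(F)c2)nc(=O)n1C`, 13.8 mL/min/kg
compound 2, `CN1CCN(c2cc(OCc3cc(F)c(Oc4ccc(Cl)c(C(F)(F)F)c4)c(F)c3)nc(=O)n2C)CC1`, 1140 mL/min/kg

Compound 1 stands lowest of the two numbers in an ADME assay on S9 fraction from liver (Rattus norvegicus, strain Wistar) for metabolic stability, tested at 0.1 uM; a lower number here means slower removal, a higher number faster removal of the compound. In that set compound 1 gives 13.8 mL/min/kg, and its nearest neighbour is compound 2, which gives 1140 mL/min/kg, a difference recorded as an 83-fold higher number from compound 1 to compound 2 (1.92 log units; beyond the scatter). The unmeasured compound 3, `Cn1c(N2CCN(C3CC3)CC2)cc(OCc2cc(F)c(Oc3ccc(Cl)c(C(F)(F)F)c3)c(F)c2)nc1=O`, differs from compound 1 in one place: 4-cyclopropylpiperazin-1-yl in place of ((ethoxycarbonyl)methyl)(methyl)amino on an aromatic carbon. For the measured compounds named here, the only measured step that bears on this change is the one from compound 1 to compound 2, where the same position took on a closely related piperazinyl group and the number rose sharply, an 83-fold higher number from compound 1 to compound 2 (1.92 log units; beyond the scatter). Compound 3 is therefore expected to move in the same direction, by a large step, a 58-fold higher number from compound 1 to compound 3 (1.76 log units; beyond the scatter). The estimate for compound 3 in this assay is 800 mL/min/kg, with a range from 250 mL/min/kg to 2500 mL/min/kg.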

Compound 3, clearance: 13.7 mL/min/kg
For compound 3 the middle estimate is 58-fold (1.77 log units) above the measured one; measured number outside the range, below it.
By their numbers in this assay, from the lowest: compounds 3 and 1 (each within the scatter of the next); then compound 2.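

In this assay, 4-cyclopropylpiperazin-1-yl in place of ((ethoxycarbonyl)methyl)(methyl)amino on this aromatic carbon gives a step within the scatter (a 1.0-fold lower number from compound 1 to compound 3 (0.00 log units; within the scatter)), so a piperazine ring here does not by itself go with the large rise of compound 2, and the outcome turns on the group on the ring amine nitrogen, where cyclopropyl in place of methyl gives a large step (an 83-fold lower number from compound 2 to compound 3 (1.92 log units; beyond the scatter)). Nothing available accounts for this difference between methyl and cyclopropyl. The compounds shown leave open how an ethyl or isopropyl group on that nitrogen would compare with methyl and cyclopropyl. They also leave open whether the hydrogen-bearing piperazine, or a morpholine in its place, would stand nearer compound 2 or compound 3.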